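The source may hold more compounds than are shown below. What is called first, only, known or untested is meant among the compounds shown, and "the series" means these compounds.

Measured in a functional assay on A-375 cells (Homo sapiens) for cytotoxicity, read by CCK-8 assay, with a stated time of 24 h; on this read-out higher numbers stand for weaker inhibition and lower numbers for stronger inhibition:
- compound 1 `COc1ccccc1Oc1c(N)nc(Cc2ccccc2)nc1OCCO`: 200 nM
- compound 2 `COc1ccccc1Oc1c(N)nc(-c2ccccc2F)nc1OCCO`: > 80000 nM, a limit of the assay
- compound 3 `COc1ccccc1Oc1c(N)nc(-c2ccc(F)cc2)nc1OCCO`: 15900 nM

Of the two true numbers in this assay, the higher belongs to compound 3, at 15900 nM. The benzyl analogue lies far below it, with an 80-fold higher number from compound 1 to compound 3 (1.90 log units; beyond the scatter).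

Compound 4 `COc1ccccc1Oc1c(N)nc(-c2cccc(I)c2)nc1OCCO` carries 3-iodophenyl in place of 4-fluorophenyl on an aromatic carbon, between two ring nitrogen atoms: 3-iodophenyl in place of 4-fluorophenyl on an aromatic carbon.

Within the data shown here, three measured steps bear on this change. Replacing benzyl with an aryl group was costly both in an at least 400-fold higher number from compound 1 to compound 2 (2.60 log units; beyond the scatter) and in an 80-fold higher number from compound 1 to compound 3 (1.90 log units; beyond the scatter). Among the aryl compounds, the fluorine position mattered, with an at least 5.0-fold lower number from compound 2 to compound 3 (0.70 log units; beyond the scatter). Among the measured compounds shown here, no measured compound carries iodine, so the direction is poorly fixed. Compound 4 keeps the directly attached aryl group, so no large return towards compound 1 is expected.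

The expected change is small, a 1.3-fold lower number from compound 3 to compound 4 (0.12 log units; within the scatter). For compound 4 the estimated value is 12000 nM, with an expected range from 3000 nM to 60000 nM.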

Compound 4, half-maximal inhibitory concentration: 1230 nM
Compound 4: the middle estimate sits 9.8-fold (0.99 log units) above what was measured; the measured number lies below the stated range.
By their numbers in this assay, from the lowest: compound 1; then compound 4; then compound 3. At a limit, above all of these: compound 2.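

In this assay, a directly attached aryl group at this position, between two ring nitrogen atoms, does not have to give a weak result: 3-iodophenyl in place of 4-fluorophenyl brings a 13-fold lower number from compound 3 to compound 4 (1.11 log units; beyond the scatter). Against the 2-fluorophenyl analogue the change is an at least 65-fold lower number from compound 2 to compound 4 (1.81 log units; beyond the scatter), although this step rests on a limit of the assay held by compound 2: the limit of > 80000 nM in this assay, at which 1 of the 4 values shown sits. Even so, 3-iodophenyl does not recover the level of the benzyl group, with a 6.2-fold higher number from compound 1 to compound 4 (0.79 log units; beyond the scatter).

The compounds shown leave open whether the halogen or its place on the ring carries the change, since 3-iodophenyl differs from 4-fluorophenyl in both. From the compounds shown here alone, how 3-fluorophenyl, 4-iodophenyl or a 3-iodobenzyl group would read at this position also remains open.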